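Swapping the bromophenyl arm for a chloropropyl chain

The source may hold more compounds than are shown below. What is called first, only, known or untested is meant among the compounds shown, and "the series" means these compounds.

Measured so far:
compound 1 `O=C1O[C@H]([C@@H](O)Cn2cc(-c3ccc(Br)cc3)nn2)C(OCc2ccccc2)=C1OCc1ccccc1` gives 5100 nM
compound 2 `CCCCc1cn(C[C@H](O)[C@H]2OC(=O)C(OCc3ccccc3)=C2OCc2ccccc2)nn1` gives 26300 nM
compound 3 `COc1ccccc1-c1cn(C/C=C2\OC(=O)C(OCc3ccccc3)=C2OCc2ccccc2)nn1` gives only a limit, > 100000 nM

All three were tested in an ADME assay on HFF cells (Homo sapiens) for cytotoxicity, read by MTT assay, with a stated time of 72 h; a higher number here means a weaker inhibitor, a lower number a stronger inhibitor. Compound 1 gives 5100 nM, the lowest of the two numbers shown. Going by the values given here, compound 2 sits higher, the sole measured step being a 5.2-fold higher number from compound 1 to compound 2 (0.71 log units; beyond the scatter). Compound 3 reports no number but a limit: the limit of > 100000 nM in this assay, at which 1 of the 3 values shown sits.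

Compound 4 `O=C1O[C@H]([C@@H](O)Cn2cc(CCCCl)nn2)C(OCc2ccccc2)=C1OCc1ccccc1` has not been measured. It differs from compound 1 by 3-chloropropyl in place of 4-bromophenyl on an aromatic carbon. Among the compounds with values here, the only step that bears on this is a 5.2-fold higher number from compound 1 to compound 2 (0.71 log units; beyond the scatter), where a chain likewise took the place of the 4-bromophenyl group. A step of similar size, toward a higher number, is therefore expected: a 3.9-fold higher number from compound 1 to compound 4 (0.59 log units; beyond the scatter). Compound 4 is estimated at 20000 nM, within 8000 nM to 60000 nM.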

Compound 4, half-maximal inhibitory concentration: 27100 nM
For compound 4 the middle estimate is 1.4-fold (0.13 log units) below the measured one; the measured number falls inside the stated range.
By their numbers in this assay, from the lowest: compound 1; then compounds 2 and 4 (each within the scatter of the next). At a limit, above all of these: compound 3.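

A second chain in place of 4-bromophenyl on this aromatic carbon gives a 5.3-fold higher number from compound 1 to compound 4 (0.73 log units; beyond the scatter) and so lands in the same range as the butyl chain of compound 2. Chloro in place of methyl, three bonds along the chain from an aromatic carbon, gives a 1.0-fold higher number from compound 2 to compound 4 (0.01 log units; within the scatter) and thus no readable difference between these two chains. Nothing shown here explains why compound 1 has the lowest number.

On these data alone, it remains open whether a longer chain, or an amine or a carboxylic acid at the chain end, would also match these two chains. As far as these compounds go, whether a plain phenyl would stay close to compound 1 is equally open.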